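Aryl exchange on the ester chain: compound 3 to compound 4

The source may hold more compounds than are shown below. What is called first, only, known or untested is meant among the compounds shown, and "the series" means these compounds.

Three compounds carry numbers in an assay on thoracic aorta for inhibition of Voltage-gated L-type calcium channel (Rattus norvegicus); a higher number here means a weaker inhibitor, a lower number a stronger inhibitor. Compound 1 `CCC1=C(C(=O)OC/C=C/c2ccccc2)C(c2cccc(Cl)c2)C(C(=O)O)=C(C)N1` gives 7 nM. Compound 2 `COC(OC)C1=C(C(=O)O)C(c2cccc(Cl)c2)C(C(=O)OC/C=C/c2ccccc2)=C(C)N1` gives 1300 nM. Compound 3 `COC(OC)C1=C(C(=O)OC/C=C/c2cccc(Cl)c2)C(c2cccc(Cl)c2)C(C(=O)O)=C(C)N1` gives 1000 nM, the second highest of the three; compound 2 lies within the scatter of it, so nothing separates the two, while compound 1 lies far lower, well beyond the scatter. Compound 4 `COC(OC)C1=C(C(=O)OC/C=C/c2ccc(C(F)(F)F)cc2)C(c2cccc(Cl)c2)C(C(=O)O)=C(C)N1` carries 4-(trifluoromethyl)phenyl in place of 3-chlorophenyl on a double-bonded chain carbon bound to a double-bonded chain carbon. Within the data shown here, no measured pair shows this change, so its size rests on no measured step. The expected step is no change at the digits printed from compound 3 to compound 4 (within the scatter), in either direction no larger than the scatter. Compound 4 is estimated at 1000 nM in this assay, between 300 nM and 3500 nM.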

Compound 4, half-maximal inhibitory concentration: 3200 nM
Compound 4: middle estimate off by 3.2-fold (0.51 log units), on the low side, and the stated range covers the measured number.
By their numbers in this assay, from the lowest: compound 1; then compounds 3 and 2 (each within the scatter of the next); then compound 4.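

In this assay, among these compounds, the aryl group on this ester chain is not silent: 4-(trifluoromethyl)phenyl in place of 3-chlorophenyl on a double-bonded chain carbon bound to a double-bonded chain carbon gives a 3.2-fold higher number from compound 3 to compound 4 (0.51 log units; beyond the scatter) and is the first single-place step. This one step gives a direction for one exchange only, and no measurement on hand accounts for it.

Open, from the compounds shown here alone, is how a pyridine ring or an amine would read in place of either aryl group on this chain. Also open, going by these compounds, is whether the same exchange carries over to the core of compound 1.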